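Benzimidazole-pyrazole cytotoxicity series: removing the carbonyl-ring methyl

The source may hold more compounds than are shown below. What is called first, only, known or untested is meant among the compounds shown, and "the series" means these compounds.

Measured compounds in an ADME assay on HEK-293T cells (Homo sapiens) for cytotoxicity, read by MTT assay, with a stated time of 24 h; a higher number here means that more compound is tolerated, a lower number that less compound is tolerated:

compound 1 `Cc1ccc(-c2nn(-c3ccccc3)cc2-c2nc3ccccc3n2C(=O)c2ccccc2C)cc1`: 176000 nM
compound 2 `Cc1ccccc1C(=O)n1c(-c2cn(-c3ccccc3)nc2-c2ccc(F)cc2)nc2ccccc21`: 189000 nM
compound 3 `Cc1ccc(C(=O)n2c(-c3cn(-c4ccccc4)nc3-c3ccc(C(F)(F)F)cc3)nc3ccccc32)cn1`: 153000 nM

Compound 2 stands highest of the three numbers, but both neighbours lie within the scatter of it: compound 1 sits closest, compound 3 furthest, and neither gap counts as a real difference. Within the data shown here, the only single-point step among the measured compounds, a 1.1-fold higher number from compound 1 to compound 2 (0.03 log units; within the scatter), concerns a substituent on the aryl group attached to the pyrazole and falls within the scatter.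

Compound 4 `O=C(c1ccccc1)n1c(-c2cn(-c3ccccc3)nc2-c2ccc(F)cc2)nc2ccccc21` is not yet measured. It differs from compound 2 as follows: hydrogen in place of methyl on an aromatic carbon. Among the measured compounds shown here, this change sits on the acyl group rather than on the pyrazole aryl, so no measured step addresses it directly. The three measured values, with their varied aryl substituents and acyl groups, all lie within a narrow band, which gives no reason to expect a departure from it. The step of a 1.1-fold lower number from compound 2 to compound 4 (0.02 log units; within the scatter) is therefore expected to stay within the scatter, with no direction favoured. Compound 4 is estimated at 180000 nM in this assay, with a range of 100000 nM to 320000 nM.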

Compound 4, half-maximal cytotoxic concentration: 180000 nM
Compound 4: middle estimate and measured number agree at the digits printed; measured number inside the range.
By their numbers in this assay, from the lowest: compounds 3, 1, 4 and 2 (each within the scatter of the next).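

In this assay, among these compounds, the step of a 1.1-fold lower number from compound 2 to compound 4 (0.02 log units; within the scatter) is the first measured single-place change on the acyl side of the series, where 2-methylphenyl is replaced by phenyl, and it lies within the scatter. For this pair, the methyl ortho to a large group can therefore be exchanged for hydrogen with no readable difference in the tolerated concentration, although one pair sets no rule for the series. No available evidence bears on this result.

On these data alone, whether an amine, a carboxylic acid or a longer chain at this place would stay within the scatter of compound 4 remains open. Also open, as far as these compounds go, is whether the same exchange of methyl for hydrogen reads alike when the pyrazole aryl carries the methyl of compound 1 instead of fluoro.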